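This account rests on a few compounds, and the source may have more. Where it says the series, first, only, none or still open, it means among the compounds named here.

Measured so far:
Compound 1, `CN(C)CC[C@H](CSc1ccccc1)Nc1ccc(S(=O)(=O)NC(=O)c2ccc(N3CCN(Cc4ccccc4-c4ccc(Cl)cc4)CC3)cc2)cc1C(F)(F)F`, in an assay on isolated protein for displacement of a labelled ligand from Bcl2-associated agonist of cell death (Homo sapiens), read by fluorescence polarization (on this read-out higher numbers stand for weaker inhibition and lower numbers for stronger inhibition), gives < 1 nM, which is a limit of the assay rather than a number.
Compound 2, `CN(C)CC[C@H](CSc1ccccc1)Nc1ccc(S(=O)(=O)NC(=O)c2ccc(N3CCN(CC4=C(c5ccc(Cl)cc5)CCCC4)CC3)cc2)cc1[N+](=O)[O-]`, in this assay gives < 1 nM, also a limit.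
Compound 3, `O=C(NS(=O)(=O)c1ccc(NCCSc2ccccc2)c([N+](=O)[O-])c1)c1ccc(N2CCN(Cc3ccccc3-c3ccc(Cl)cc3)CC2)cc1`, in this assay gives < 1 nM, again a limit.

Compound 1 therefore stands exactly where every measured compound stands: no number is known for it, only (the limit of < 1 nM in this assay, at which 3 of the 3 values shown sit). For the measured compounds named here, nothing among the measured compounds separates one from another.

Compound 4, `CN(C)CC[C@H](CSc1ccccc1)Nc1ccc(S(=O)(=O)NC(=O)c2ccc(N3CCN(Cc4ccccc4-c4ccc(Cl)cc4)CC3)cc2)cc1C(=O)C(F)(F)F`, is the one still to be measured in this assay. It differs from compound 1 in one place: (trifluoromethyl)carbonyl in place of trifluoromethyl on an aromatic carbon. Going by the values given here, no step between two measured compounds is available that would show how such a change plays out here, so the expectation rests on the position of compound 1 alone. The change is expected to give a step of no size beyond the usual scatter, a step that the limit leaves unreadable from compound 1 to compound 4. Compound 4 is thus estimated at 0.7 nM, with a range from 0.2 nM to 3 nM, and most likely again reported only as a limit.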

Compound 4, inhibition constant: < 1 nM
Compound 4 was reported as a limit; the forecaster's own chance of this, stated with the estimate: 75%; the middle value does not contradict the limit.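

Compound 4, like compound 1, is reported only as a limit, so no step can be read between them: the limit of < 1 nM in this assay, at which 4 of the 4 values shown sit.

The compounds shown leave open whether (trifluoromethyl)carbonyl and trifluoromethyl differ at all in this assay, and how strongly any of these compounds truly binds.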